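The compounds below may be only part of what the source reports. "The series", "measured", "known", "first", "only" and "open" are said of these compounds alone.

Compound 1 `COc1ccc(NC(=O)c2cccc(/C=C3\CC(=O)N(c4ccccc4)C3=O)c2)cc1`: > 100000 nM
Compound 2 `O=C(c1cccc(/C=C2\CC(=O)N(c3ccccc3)C2=O)c1)N1CCCC1`: > 100000 nM

In an ADME assay on HCT-116 cells (Homo sapiens) for cytotoxicity, read by MTT assay, with a stated time of 72 h (on this read-out higher numbers stand for weaker inhibition and lower numbers for stronger inhibition), compound 1 gives > 100000 nM, which is a limit of the assay and not a number. Compound 2, carrying pyrrolidin-1-yl on the carbonyl carbon in place of (4-methoxyphenyl)amino, gives > 100000 nM, again a limit rather than a number. The step that the two limits leave unreadable from compound 1 to compound 2 is therefore unreadable. Compound 2 thus stands at the limit of > 100000 nM in this assay, at which 2 of the 2 values shown sit, and nothing finer is known about it. Compound 3 `CSc1cccc(NC(=O)c2cccc(/C=C3\CC(=O)N(c4ccccc4)C3=O)c2)c1` differs from compound 2 in one place: (3-(methylsulfanyl)phenyl)amino in place of pyrrolidin-1-yl on a carbonyl carbon. Among the compounds with values here, the single measured step bears on this change only loosely, as it runs the other way, from an arylamino group to the amine ring, and its size cannot be read. No measured step therefore gives reason to expect a move in this assay beyond the scatter, and compound 3 is expected to stay at the limit. The estimate for compound 3 is 100000 nM, within 30000 nM to 300000 nM. The expected step of a number no higher from compound 2 to compound 3 (the limit leaves the size open) is essentially none.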

Compound 3, half-maximal inhibitory concentration: 65200 nM
The estimate for compound 3 lay 1.5-fold (0.19 log units) above the measured number; low and high end bracket the measured number.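

In this assay compound 3 gives 65200 nM, a true number rather than a limit, so a group on this carbonyl carbon can bring the read-out inside the range of the assay. Replacing pyrrolidin-1-yl with (3-(methylsulfanyl)phenyl)amino gives an at least 1.5-fold lower number from compound 2 to compound 3 (0.18 log units; that floor lies within the scatter), and exchanging 4-methoxyphenyl for 3-(methylsulfanyl)phenyl on the amide-type nitrogen gives an at least 1.5-fold lower number from compound 1 to compound 3 (0.18 log units; that floor lies within the scatter), so neither step on its own shows a real change. The other two compounds remain limits, not numbers, and their true values could lie anywhere beyond them: the limit of > 100000 nM in this assay, at which 2 of the 3 values shown sit.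

From the compounds shown here alone, how far each step really reaches stays open, since only its floor can be read. Also open, going by these compounds, is whether a morpholine ring on the carbonyl carbon, or an unsubstituted phenyl on the amide-type nitrogen, would give a number or a limit.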